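Hydrazine nitrogen substituents on a shared thiadiazole-type core

The compounds below may be only part of what the source reports. "The series", "measured", "known", "first", "only" and "open" are said of these compounds alone.

Compound 1 `Cc1ccccc1-c1nnc(NN)s1`: 30 mg/kg
Compound 2 `CNNc1nnc(-c2ccccc2C)s1`: > 100 mg/kg
Compound 3 `Cc1ccccc1-c1nnc(NNC2CCCC2)s1`: > 100 mg/kg

In a functional assay on the whole organism with Mus musculus as the target, with a stated time of 1 h (on this read-out lower numbers stand for an effect already at smaller amounts and higher numbers for an effect only at larger amounts of compound), compound 1 gives 30 mg/kg. For compound 2 the value > 100 mg/kg is a limit of the assay, not a number. For compound 3 the value > 100 mg/kg is likewise a limit; compound 3 thus stands at the limit of > 100 mg/kg in this assay, at which 2 of the 3 values shown sit. The two steps away from compound 1 were an at least 3.3-fold higher number from compound 1 to compound 2 (0.52 log units; beyond the scatter) and an at least 3.3-fold higher number from compound 1 to compound 3 (0.52 log units; beyond the scatter), while a step that the two limits leave unreadable from compound 2 to compound 3.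

Compound 4 `Cc1ccccc1-c1nnc(NNc2ccccc2)s1` differs from compound 3 by phenyl in place of cyclopentyl on an amine nitrogen. Among the measured compounds shown here, no measured step tests a phenyl here; both measured substitutions on this nitrogen moved the number upward. Compound 4 is therefore expected to stay at or near the limit, with an estimate of 150 mg/kg (50 mg/kg to 500 mg/kg), which means an expected step that the limit leaves unreadable from compound 3 to compound 4.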

Compound 4, dose for half-maximal effect: > 100 mg/kg
Compound 4: a limit, no number; the forecaster's own chance of this, stated with the estimate: 65%; the middle value lies beyond the limit too.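

Phenyl on this amine nitrogen gives an at least 3.3-fold higher number from compound 1 to compound 4 (0.52 log units; beyond the scatter), so an aromatic ring, like methyl and cyclopentyl, does not keep the number seen with hydrogen there. The steps among the three substituted compounds cannot be read, so they give no order among methyl, cyclopentyl and phenyl. The substituted compounds now form a plateau in the data: the limit of > 100 mg/kg in this assay, at which 3 of the 4 values shown sit.

From the compounds shown here alone, how far past the limit these compounds lie remains open. So does whether an acetyl group or a chain ending in a carboxylic acid on this nitrogen would return a readable number.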